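The source may hold more compounds than are shown below. What is called first, only, known or untested is meant among the compounds shown, and "the series" means these compounds.

Compound 1 `CNc1nc(NC(C)(C)C)c2sc(-c3ccc(C(F)(F)F)cc3)cc2n1`: < 1.6 ug/mL
Compound 2 `CNc1nc(NC2CCOCC2)c2sc(-c3ccc(C(F)(F)F)cc3)cc2n1`: < 5 ug/mL

Of the compounds shown here, two sharing one core have been measured in a physicochemical assay for solubility, in phosphate buffer, at pH 6.5; a lower number here means a less soluble compound, a higher number a more soluble compound. For compound 1 the value < 1.6 ug/mL is a limit of the assay and not a number. For compound 2 the value < 5 ug/mL is likewise a limit. Compound 1 thus sits at the limit of < 1.6 ug/mL in this assay, at which 1 of the 2 values shown sits, and compound 2 stands at the limit of < 5 ug/mL in this assay, at which 1 of the 2 values shown sits. For the measured compounds named here, the single measured step, a step that the two limits leave unreadable from compound 1 to compound 2, therefore has a size that cannot be read.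

Compound 3 `CNc1nc(Nc2cccc(C(N)=O)c2)c2sc(-c3ccc(C(F)(F)F)cc3)cc2n1` differs from compound 2 by 3-carbamoylphenyl in place of oxan-4-yl on a nitrogen on an aromatic ring. Going by the values given here, no measured step bears on this change in a readable way, since the one step between compounds 1 and 2 shows only that both sit at limits. Compound 3 is expected to stay close to those limits, with a step that the limit leaves unreadable from compound 2 to compound 3 that is not expected to go beyond the scatter. The estimate for compound 3 in this assay is 2 ug/mL, with a range from 0.5 ug/mL to 8 ug/mL.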

Compound 3, solubility: 8 ug/mL
For compound 3 the middle estimate is 4.0-fold (0.60 log units) below the measured one; the measured number falls inside the stated range.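

In this assay, for the compounds shown here, compound 3 is the only one of the three compounds with a measured number rather than a limit, and with 3-carbamoylphenyl on this nitrogen the change from tert-butyl reads as an at least 5.0-fold higher number from compound 1 to compound 3 (0.69 log units; beyond the scatter). The change from oxan-4-yl reads only as an at least 1.6-fold higher number from compound 2 to compound 3 (0.20 log units; that floor lies within the scatter), so this comparison alone does not establish a gain over compound 2. Compound 2 has a limit and not a number: the limit of < 5 ug/mL in this assay, at which 1 of the 3 values shown sits.

On these data alone, the step between compound 1 and compound 2 cannot be read, so the order of tert-butyl and oxan-4-yl remains open. Also open, as far as these compounds go, is whether the aromatic ring or its carboxamide accounts for the number given by compound 3, which a plain phenyl group, or a phenyl group carrying a carboxylic acid or an amine instead, could help to separate.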